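Filling the gap in a sulfooxy chain series

This account rests on a few compounds, and the source may have more. Where it says the series, first, only, none or still open, it means among the compounds named here.

Measured in a functional assay on RAW264.7 cells (Mus musculus) for cytotoxicity, read by MTT assay, with a stated time of 24 h (a lower number here means a stronger inhibitor, a higher number a weaker inhibitor), so far:
Compound 1 `O=S(=O)(O)OCCCCCCCCCC[Se]c1ccccc1` gives > 100000 nM (a limit)
Compound 2 `O=S(=O)(O)OCCCCCCCC[Se]c1ccccc1` gives > 100000 nM (a limit)

Compound 2 stands at > 100000 nM as a limit of the assay, not a number. Compound 3 `O=S(=O)(O)OCCCCCCCCC[Se]c1ccccc1` has not been measured yet. It carries (sulfooxy)methyl in place of sulfooxy on a saturated chain carbon, eight bonds along the chain from a selenium atom. Counted out, the change is (sulfooxy)methyl in place of sulfooxy on a saturated chain carbon, eight bonds along the chain from a selenium atom and nothing else differs.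

Among the compounds with values here, the one measured step that bears on this is a step that the two limits leave unreadable from compound 1 to compound 2 and it gives no size to build on. That step runs from 2-(sulfooxy)ethyl to sulfooxy, and (sulfooxy)methyl stands part of the way along it. With compound 1 and compound 2 both covered by the limit of > 100000 nM in this assay, at which 2 of the 2 values shown sit, in the record, no change beyond the scatter is expected in this assay in either direction. The expected step that the limit leaves unreadable from compound 2 to compound 3 is therefore no real shift. Compound 3 is expected at 120000 nM with an estimated range from 60000 nM to 300000 nM and will most likely be reported only as a limit.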

Compound 3, half-maximal inhibitory concentration: > 100000 nM
Compound 3: no number, only a limit (the forecaster's own chance of this, stated with the estimate: 90%); the middle value does not contradict the limit.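

In this assay compound 3 gives > 100000 nM, which is a limit and not a number. No step among compound 1, compound 2 and compound 3 can be read, because all three rest on the same limit: the limit of > 100000 nM in this assay, at which 3 of the 3 values shown sit.

As far as these compounds go, whether these three compounds differ at all in this assay, and by how much, stays open.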